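Amide variation on the stilbene acrylamide series

The source may report more compounds than this note shows. Statements on the series, on what has been measured and on what is new or still open speak of the compounds shown alone.

Measured so far in a functional assay on B16-F10 cells (Mus musculus) for inhibition, read by MTT assay, with a stated time of 48 h; on this read-out higher numbers stand for weaker inhibition and lower numbers for stronger inhibition:
- compound 1, `CCCCNC(=O)/C=C/c1c(/C=C/c2ccc(OC)cc2)cc(OC)cc1OC`, 2080 nM
- compound 2, `C#CCNC(=O)/C=C/c1c(/C=C/c2ccc(OC)cc2)cc(OC)cc1OC`, 8280 nM
- compound 3, `COc1ccc(/C=C/c2cc(OC)cc(OC)c2/C=C/C(=O)N2CCC(Cl)CC2)cc1`, 4690 nM

Compound 2 gives the highest of the three numbers in this assay; its nearest neighbour is compound 3, a 1.8-fold lower number from compound 2 to compound 3 (0.25 log units; within the scatter), and the furthest is compound 1, a 4.0-fold higher number from compound 1 to compound 2 (0.60 log units; beyond the scatter).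

Compound 4, `COc1ccc(/C=C/c2cc(OC)cc(OC)c2/C=C/C(=O)N2CCCC(C)C2)cc1`, is not yet measured. It differs from compound 2 as follows: 3-methylpiperidin-1-yl in place of propargylamino on a carbonyl carbon.

Among the measured compounds shown here, the step closest in kind is the one to compound 3, where a piperidin-1-yl ring likewise replaces propargylamino on the carbonyl carbon: a 1.8-fold lower number from compound 2 to compound 3 (0.25 log units; within the scatter). The step from the butylamino amide to that ring, a 2.3-fold higher number from compound 1 to compound 3 (0.35 log units; beyond the scatter), shows that the ring amides sit near the middle of the small spread seen here. For the measured compounds named here, no step with 3-methylpiperidin-1-yl itself is available. On this basis a small lowering of the number, not clearly beyond the scatter, is expected for compound 4: a 1.8-fold lower number from compound 2 to compound 4 (0.26 log units; within the scatter). The estimate for compound 4 in this assay is 4500 nM, with a range from 2000 nM to 10000 nM.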

Compound 4, half-maximal inhibitory concentration: 8250 nM
Compound 4: the middle estimate sits 1.8-fold (0.26 log units) below what was measured, within the range that was stated.
By their numbers in this assay, from the lowest: compound 1; then compounds 3, 4 and 2 (each within the scatter of the next).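

In this assay, the 3-methylpiperidin-1-yl amide cannot be separated from the propargylamino amide (a 1.0-fold lower number from compound 2 to compound 4 (0.00 log units; within the scatter)) or from the 4-chloropiperidin-1-yl amide (a 1.8-fold higher number from compound 3 to compound 4 (0.25 log units; within the scatter)), so compounds 2, 3 and 4 now form one group despite their different groups on the carbonyl carbon. Only the butylamino amide stands apart from the new ring amide (a 4.0-fold higher number from compound 1 to compound 4 (0.60 log units; beyond the scatter)), and the amide hydrogen does not explain this split, since compound 2 keeps that hydrogen yet groups with the two ring amides. No available measurement bears on why these amides group in this way.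

From the compounds shown here alone, it remains open whether an unsubstituted piperidin-1-yl or a morpholin-4-yl amide would fall with compounds 2, 3 and 4. Going by these compounds, it is also open whether a pentylamino or hexylamino chain would match compound 1 or move further from that group.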